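Swapping the Aryl Group on a Sulfone Core

A few compounds are considered here, and "the series" means these few. Any claim that something is new, unique, unknown or untested is made for them only; others in the source may bear on it.

Measured so far:
compound 1, `Nc1ccc(Sc2cc(N)c3ncccc3c2[N+](=O)[O-])cc1`: > 10000 nM
compound 2, `COc1ccc(S(=O)(=O)c2cc(N)c3ncccc3c2[N+](=O)[O-])cc1`: 1140 nM

Both compounds were tested in an assay for binding affinity to Neuropeptide Y receptor type 1 (Homo sapiens), read by radioligand binding; a higher number here means a weaker inhibitor, a lower number a stronger inhibitor. For compound 1 the result is only a limit of the assay, not a number. Compound 2 therefore stands alone with the single number shown, so there is no measured step in this series to lean on; the other entry is the limit of > 10000 nM in this assay, at which 1 of the 2 values shown sits.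

The next compound, compound 3, `Nc1cc(S(=O)(=O)c2ccccc2Cl)c([N+](=O)[O-])c2cccnc12`, shares the core of compound 2 and differs in one place: 2-chlorophenyl in place of 4-methoxyphenyl on a sulfonyl sulfur. For the measured compounds named here, no measured pair shows what such an exchange does here, so the direction is open. The expectation for the step from compound 2 to compound 3 is a 1.3-fold higher number from compound 2 to compound 3 (0.12 log units; within the scatter), a shift that need not exceed the usual scatter. Compound 3 is thus expected near 1500 nM, with a likely range from 400 nM to 6000 nM.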

Compound 3, inhibition constant: 93 nM
Beside the measured number, compound 3's estimate is 16-fold (1.21 log units) above it; the measured number lies below the stated range.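

Within this assay, exchanging 4-methoxyphenyl for 2-chlorophenyl on a sulfonyl sulfur gives a 12-fold lower number from compound 2 to compound 3 (1.09 log units; beyond the scatter), so the group held at this position has a strong influence on the reading. For the compounds shown here, this is the first measured step, and it is large even though the group entering and the group leaving both contain one six-membered aromatic ring of carbon only. Nothing measured here accounts for the size or direction of this step.

The exchange alters both the atom on the ring and the number in the group's name, so the compounds shown leave open which of the two matters; 4-chlorophenyl or 2-methoxyphenyl on the same sulfur would separate them. Going by these compounds, it also remains open how a group without an aromatic ring, such as a simple ethyl chain, would fare here.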